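A few compounds are considered here, and "the series" means these few. Any claim that something is new, unique, unknown or untested is made for them only; others in the source may bear on it.

Of the compounds shown here, two have been measured so far in a functional assay on QGY-7703 cells (Homo sapiens) for cytotoxicity, read by MTT assay, with a stated time of 24 h (a lower number here means a stronger inhibitor, a higher number a weaker inhibitor), and both sit close together. Compound 1 (`N#Cc1ccc(/C=C2\CN(S(=O)(=O)c3ccc(F)cc3)C/C(=C\c3ccc(C#N)cc3)C2=O)cc1`) gives 11300 nM and compound 2 (`COc1cc(/C=C2\CN(S(=O)(=O)c3ccc(F)cc3)C/C(=C\c3ccccc3F)C2=O)cc(OC)c1OC`) gives 13300 nM in this test. These two numbers lie within the scatter of repeated measurements, so compound 2 stands level with compound 1 and neither can be ranked over the other.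

The next molecule, compound 3 (`COc1cc(/C=C2\CN(S(=O)(=O)c3ccc(F)cc3)C/C(=C\c3ccc(C#N)cc3)C2=O)cc(OC)c1OC`), has not been measured yet. It differs from compound 2 in one place: 4-cyanophenyl in place of 2-fluorophenyl on a double-bonded chain carbon bound to a double-bonded ring carbon. The count for that change reads 4-cyanophenyl in place of 2-fluorophenyl on a double-bonded chain carbon bound to a double-bonded ring carbon and nothing else in the structure differs.

Among the measured compounds shown here, no measured pair shows this swap on its own, so the data give no direct size for it. Compound 1 carries 4-cyanophenyl and gives 11300 nM while compound 2 lacks it and gives 13300 nM in a similar range. The expectation in this assay is therefore no step beyond the scatter, in either direction. The estimate amounts to a 1.1-fold lower number from compound 2 to compound 3 (0.04 log units; within the scatter) and stays within that scatter. Compound 3 is expected at 12000 nM with an estimated span of 6000 nM to 24000 nM as its likely range.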

Compound 3, half-maximal inhibitory concentration: 4980 nM
The estimate for compound 3 lay 2.4-fold (0.38 log units) above the measured number; the measured number lies below the stated range.
By their numbers in this assay, from the lowest: compound 3; then compounds 1 and 2 (each within the scatter of the next).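

In this assay, 4-cyanophenyl in place of 2-fluorophenyl on a double-bonded chain carbon bound to a double-bonded ring carbon gives a 2.7-fold lower number from compound 2 to compound 3 (0.43 log units; beyond the scatter) and so provides the first measured size for this swap, with the rest of the structure unchanged. The step is modest, but it shows that the group at this position can shift the number beyond the scatter, which the two earlier compounds, differing in more than one place, could not show. Compound 3 also forms a pair with compound 1, where 3,4,5-trimethoxyphenyl in place of 4-cyanophenyl at the same kind of place gives a 2.3-fold lower number from compound 1 to compound 3 (0.36 log units; beyond the scatter) and shows that, among these three compounds, the mixed pairing of 3,4,5-trimethoxyphenyl with 4-cyanophenyl has the lowest number.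

The compounds shown leave open whether the nitrile, the removal of fluorine or the change in where the substituent sits on the ring accounts for the step, and a plain phenyl, a 4-fluorophenyl or a 2-cyanophenyl at this position would help separate these. Nothing available explains why either step occurs.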